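Two Bromines, One Amide, and Nothing Measurable Yet

A few compounds are considered here, and "the series" means these few. Any claim that something is new, unique, unknown or untested is made for them only; others in the source may bear on it.

Three compounds with a shared amide-linked core were examined in an assay on isolated protein for inhibition of thiosulfate sulfurtransferase (Homo sapiens), with a stated time of 60 min, in the absence of a further agent; on this read-out lower numbers stand for stronger inhibition and higher numbers for weaker inhibition: compound 1 `O=C(Nc1cccc(Cl)c1)c1cc(Br)cc(Br)c1O`, compound 2 `COc1c(Br)cc(Br)cc1C(=O)Nc1ccccc1` and compound 3 `O=C(Nc1ccccc1)c1cc(Br)ccc1O`. Compound 1 reaches only the limit of the assay, > 100000 nM. Compound 2 likewise gives only a limit, > 100000 nM. Compound 3 also stops at a limit, > 100000 nM. Compound 2 therefore stands exactly where every other measured value stands, at the limit of > 100000 nM in this assay, at which 3 of the 3 values shown sit, with no number to set it apart from its neighbours.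

Compound 4 `COc1c(Br)cccc1C(=O)Nc1ccccc1` has not been measured. It differs from compound 2 by hydrogen in place of bromo on an aromatic carbon; in words, hydrogen in place of bromo on an aromatic carbon. Going by the values given here, no step between two measured compounds is available, so the size of this change cannot be read from neighbours. Compound 2 gives only a limit in this assay, and nothing among the three values points toward inhibition that the assay would report as a number.

Compound 4 is therefore expected to give 100000 nM in this assay, within 30000 nM to 300000 nM. The step that this estimate means, a number no higher from compound 2 to compound 4 (the limit leaves the size open), is expected to be none beyond the scatter.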

Compound 4, half-maximal inhibitory concentration: > 100000 nM
Compound 4 was reported as a limit; the forecaster's own chance of this, stated with the estimate: 85%; the middle value sits exactly at the limit.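

Going by these compounds alone, compound 4 gives > 100000 nM as a limit and not a number, and compound 2 also gave only a limit, so no step between compound 2 and compound 4 can be read: the limit of > 100000 nM in this assay, at which 4 of the 4 values shown sit.

The compounds shown leave open whether any compound sharing this core gives a number in this assay at all.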